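A few compounds are considered here, and "the series" means these few. Any claim that something is new, unique, unknown or untested is made for them only; others in the source may bear on it.

Compound 1 `Clc1ccc(-c2cc(-c3ccoc3)cc(-c3ccc(Cl)s3)n2)cc1` measures 29500 nM
Compound 2 `Clc1cccc(-c2cc(-c3ccc(Cl)o3)cc(-c3ccc(Cl)s3)n2)c1` measures 21600 nM

Going by the values given here, both numbers come from a functional assay on DU-145 cells (Homo sapiens) for cytotoxicity, read by ELISA, with a stated time of 4 days (a higher number here means a weaker inhibitor, a lower number a stronger inhibitor), and are the only measurements so far. In this test compound 2 gives 21600 nM and so stands within the usual scatter of compound 1, with no real gap between them.

Compound 3 (`Clc1ccc(-c2cc(-c3ccc(Cl)o3)cc(-c3ccc(Cl)s3)n2)cc1`) has not been measured yet. It has the same atoms as compound 2, joined differently (4-chlorophenyl in place of 3-chlorophenyl on an aromatic carbon), with 4-chlorophenyl in place of 3-chlorophenyl next to the ring nitrogen.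

Among the compounds with values here, compound 1 and compound 2 differ in more than one place, so no measured pair shows this change alone. Compound 1 also carries 4-chlorophenyl and gives 29500 nM as its value, so no step beyond the scatter is expected in this assay for this swap. The estimate means a 1.1-fold lower number from compound 2 to compound 3 (0.03 log units; within the scatter) as the expected step. Compound 3 is estimated at 20000 nM with 8000 nM to 40000 nM as the expected range.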

Compound 3, half-maximal inhibitory concentration: 23000 nM
Compound 3: the middle estimate sits 1.2-fold (0.06 log units) below what was measured; measured number inside the range.
By their numbers in this assay, from the lowest: compounds 2, 3 and 1 (each within the scatter of the next).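

In this assay, the swap of 3-chlorophenyl for 4-chlorophenyl next to the ring nitrogen can now be read on its own (a 1.1-fold higher number from compound 2 to compound 3 (0.03 log units; within the scatter)), so on these compounds, the place of the chlorine on this phenyl group makes no real difference. Going by these compounds alone, the swap of furan-3-yl for 5-chlorofuran-2-yl on the other aromatic carbon can also be read alone for the first time (a 1.3-fold lower number from compound 1 to compound 3 (0.11 log units; within the scatter)), and it too leaves the two compounds indistinguishable. Nothing measured here explains why neither change matters in this test.

Every compound shown keeps a chlorine on its phenyl group and keeps the 5-chlorothiophen-2-yl group, so the effect of changing either remains open. An amine or a carboxylic acid in place of that phenyl chlorine, for example, might shift the number well beyond the scatter, or might not.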